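The source may hold more compounds than are shown below. What is called first, only, known or untested is meant among the compounds shown, and "the series" means these compounds.

Measured compounds:

Compound 1, `COc1cc2c(Oc3ccc(NC(=O)c4nn(-c5ccccc5F)c(=O)c5ccccc45)cc3F)ccnc2cc1OCCCN1CCCC1`: 140 nM
Compound 2, `COc1cc2c(Oc3ccc(NC(=O)c4nn(-c5ccc(Br)cc5)c(=O)c5ccccc45)cc3F)ccnc2cc1OCCCN1CCCC1`: 230 nM
Compound 3, `COc1cc2c(Oc3ccc(NC(=O)c4nn(-c5ccccc5F)c(=O)c5ccccc45)cc3F)ccnc2cc1OCCCN1CCC(C)CC1`: 260 nM

These three were tested in a functional assay on MKN-45 cells (Homo sapiens) for cytotoxicity, read by MTT assay, with a stated time of 72 h; a lower number here means a stronger inhibitor, a higher number a weaker inhibitor. Compound 4, `COc1cc2c(Oc3ccc(NC(=O)c4nn(-c5ccc(Br)cc5)c(=O)c5ccccc45)cc3F)ccnc2cc1OCCCN1CCC(C)CC1`, has not yet been tested there. Compound 4 differs from compound 3 in one place, (4-bromophenyl in place of 2-fluorophenyl on an aromatic nitrogen), and the same change has already been made once among the measured compounds, from compound 1 to compound 2, (4-bromophenyl in place of 2-fluorophenyl on an aromatic nitrogen), where it made a step of a 1.6-fold higher number from compound 1 to compound 2 (0.22 log units; within the scatter). The two places are described in identical words, so this is the same change, not merely the same kind. The two cores on which it is made differ by 4-methylpiperidin-1-yl in place of pyrrolidin-1-yl on a saturated chain carbon, three bonds along the chain from an oxygen on an aromatic ring, and that difference made a step of a 1.9-fold higher number from compound 1 to compound 3 (0.27 log units; within the scatter).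

Both measured steps fall within the usual scatter, so neither change has shown a clear effect on its own. For compound 4 a step of about a 1.5-fold higher number from compound 3 to compound 4 (0.19 log units; within the scatter) is expected, resting on the step the same change made from compound 1 to compound 2, a 1.6-fold higher number from compound 1 to compound 2 (0.22 log units; within the scatter). Compound 4 is therefore estimated at 400 nM, with a likely range from 200 nM to 800 nM.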

Compound 4, half-maximal inhibitory concentration: 330 nM
The estimate for compound 4 lay 1.2-fold (0.08 log units) above the measured number; the range from low to high includes it.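

In this assay, putting 4-bromophenyl in place of 2-fluorophenyl on the core that carries 4-methylpiperidin-1-yl gave a 1.3-fold higher number from compound 3 to compound 4 (0.10 log units; within the scatter), and this agrees with the same change on the core that carries pyrrolidin-1-yl: the same change on two cores in this assay, a 1.6-fold higher number (0.22 log units; within the scatter) from compound 1 to compound 2 and a 1.3-fold higher number (0.10 log units; within the scatter) from compound 3 to compound 4, 1.3-fold (0.11 log units) apart, within the scatter of two such steps. Putting 4-methylpiperidin-1-yl in place of pyrrolidin-1-yl on the core that carries 4-bromophenyl gave a 1.4-fold higher number from compound 2 to compound 4 (0.16 log units; within the scatter), and this too agrees with the earlier step: the same change on two cores in this assay, a 1.9-fold higher number (0.27 log units; within the scatter) from compound 1 to compound 3 and a 1.4-fold higher number (0.16 log units; within the scatter) from compound 2 to compound 4, 1.3-fold (0.11 log units) apart, within the scatter of two such steps. Across these four compounds, each change therefore behaved alike on both cores, but every step lies within the scatter, so neither change has a demonstrated effect of its own, and steps this small cannot reveal a modest dependence on the core or show how the changes would carry to other cores.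

On these data alone, it remains open whether a different group on the aromatic nitrogen, such as a 4-methoxyphenyl or a benzyl, would produce a step beyond the scatter. The same question applies to a different amine at the end of the chain, such as morpholine or dimethylamine.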